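Benzylamine sulfonamides: halophenyl swap on compound 2

This account rests on a few compounds, and the source may have more. Where it says the series, first, only, none or still open, it means among the compounds named here.

Measured so far in a functional assay on MIA PaCa-2 cells (Homo sapiens) for inhibition, read by MTT assay, with a stated time of 72 h; a lower number here means a stronger inhibitor of growth, a higher number a weaker inhibitor of growth:
compound 1 `O=[N+]([O-])c1ccc(S(=O)(=O)NCCCCCCNCc2ccc(Br)cc2)cc1` — 9800 nM
compound 2 `O=S(=O)(NCCCNCc1ccc(Cl)c(Cl)c1)c1cc(C(F)(F)F)cc(C(F)(F)F)c1` — 2700 nM

Compound 2 holds the lowest number of the two; compound 1 sits at the higher number, and the gap between them lies beyond the scatter. The two differ in more than one place, so no single change can be tied to that gap.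

Compound 3 `O=S(=O)(NCCCNCc1ccc(Br)cc1)c1cc(C(F)(F)F)cc(C(F)(F)F)c1` is the next entry. Relative to compound 2 the change is 4-bromophenyl in place of 3,4-dichlorophenyl on a saturated chain carbon bound to an amine nitrogen. Compound 1 also carries the 4-bromophenyl on a saturated chain carbon bound to an amine nitrogen, but the rest of its structure differs from compound 2, so its value does not isolate this swap. Among the measured compounds shown here, no measured pair shows this swap alone, and nothing here says which way it runs. A modest rise in the number is expected, a 1.7-fold higher number from compound 2 to compound 3 (0.22 log units; within the scatter), close to the edge of the scatter rather than clearly beyond it. For compound 3 the estimate in this assay is 4500 nM, with a range from 1800 nM to 12000 nM.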

Compound 3, concentration for 50% growth inhibition: 2300 nM
The estimate for compound 3 lay 2.0-fold (0.29 log units) above the measured number; measured number inside the range.
By their numbers in this assay, from the lowest: compounds 3 and 2 (each within the scatter of the next); then compound 1.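

In this assay, among the compounds shown here, 4-bromophenyl in place of 3,4-dichlorophenyl on a saturated chain carbon bound to an amine nitrogen gives a 1.2-fold lower number from compound 2 to compound 3 (0.07 log units; within the scatter), the first comparison that isolates a single change. On the core shared by compound 2 and compound 3, this read-out does not separate the two halophenyl groups, although one carries two chlorine atoms with 8 heavy atoms and the other one bromine atom with 7. No measurement shown explains why the two groups read alike.

As far as these compounds go, compound 1 also carries the 4-bromophenyl group, but it differs from compound 3 in more than one place, so whether this equivalence holds with its longer chain and different sulfonyl aryl group remains open. Also open, from the compounds shown here alone, is how this position responds to groups without a halogen, such as an unsubstituted phenyl, a 4-methoxyphenyl or a pyridine ring, since the two groups compared here are both halophenyl groups.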